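This account rests on a few compounds, and the source may have more. Where it says the series, first, only, none or still open, it means among the compounds named here.

Compound 2 `CC1(c2ccccc2)CC(=O)N(CC(=O)N2CCN(c3cccc(Cl)c3)CC2)C1=O` sits at 300 mg/kg in a functional assay on the whole organism (strain CD-1) with Mus musculus as the target, in the maximal electroshock model, with a stated time of 2 h (on this read-out lower numbers stand for an effect already at smaller amounts and higher numbers for an effect only at larger amounts of compound), level at the digits given with compound 1 `CC1(c2ccccc2)CC(=O)N(CC(=O)N2CCOCC2)C1=O`, which in this assay gives 300 mg/kg; the two values lie within the scatter of each other. Compound 3 `COc1ccccc1N1CCN(C(=O)CN2C(=O)CC(C)(c3ccccc3)C2=O)CC1` differs from compound 2 in one place: 2-methoxyphenyl in place of 3-chlorophenyl on an amine nitrogen in a ring. Among the measured compounds shown here, no measured pair shows this change, and the two values at hand suggest little sensitivity to the group on that ring nitrogen, so the step is expected to be none beyond the scatter, no change at the digits printed from compound 2 to compound 3 (within the scatter). Compound 3 is therefore estimated at 300 mg/kg, within 100 mg/kg to 600 mg/kg.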

Compound 3, minimum effective dose: 300 mg/kg
Compound 3: middle estimate and measured number agree at the digits printed, and the stated range covers the measured number.
By their numbers in this assay, from the lowest: compounds 1, 2 and 3 (each within the scatter of the next).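

In this assay, among the compounds shown here, putting 2-methoxyphenyl in place of 3-chlorophenyl gives no change at the digits printed from compound 2 to compound 3 (within the scatter), the first single-place change that can be read at this amine nitrogen in a ring. The swap changes both the aryl substituent and its location, and adds a hydrogen-bond acceptor, yet the read-out stays within the scatter. No evidence accompanies this result to explain it. Going by these compounds, whether a benzyl group, a pyridine ring or a simple methyl on that nitrogen would shift the value remains open. So does the response to changes elsewhere on the shared core.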